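The source may report more compounds than this note shows. Statements on the series, on what has been measured and on what is new or still open speak of the compounds shown alone.

Measured compounds and their values: compound 1 `CN(Cc1ccc(C(=O)O)cc1)c1ccc(OCc2c(-c3c(Cl)cccc3Cl)noc2C2CC2)nc1C(F)(F)F` with 12 nM; compound 2 `CC(c1ccc(OCc2c(-c3c(Cl)cccc3Cl)noc2C2CC2)nc1C(F)(F)F)N(C)c1ccc(C(=O)O)cc1` with 179 nM; compound 3 `O=C(O)c1ccc(OCc2ccc(OCc3c(-c4c(Cl)cccc4Cl)noc3C3CC3)nc2C(F)(F)F)cc1` with 76 nM.

In an assay on isolated protein for agonist activity at Bile acid receptor (Homo sapiens), read by FRET (a higher number here means that more compound is needed for the effect, a lower number that less compound is needed), compound 3 gives 76 nM, the second highest of the three numbers. Its nearest neighbour is compound 2, which gives 179 nM, a gap beyond the scatter; furthest away is compound 1, which gives 12 nM. For the measured compounds named here, the one measured step that touches compound 3 is a 6.3-fold higher number from compound 1 to compound 3 (0.80 log units; beyond the scatter), a modest change that concerns a different part of the link than the one changed next.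

Compound 4 `CC(Oc1cccc(C(=O)O)c1)c1ccc(OCc2c(-c3c(Cl)cccc3Cl)noc2C2CC2)nc1C(F)(F)F` has not yet been measured in this assay. It differs from compound 3 in that (1-(3-carboxyphenoxy)ethyl in place of (4-carboxyphenoxy)methyl on an aromatic carbon). Going by the values given here, no measured step covers this exact change. The pair of compound 1 and compound 2, however, differs by an extra methyl on the linking carbon: compound 1 gives 12 nM, and compound 2 gives 179 nM, which shows that the branched link went with a clearly higher number. The move of the carboxylic acid to the 3-position is not tested anywhere in the set. On this basis compound 4 is expected to need more compound than compound 3, a step of a 4.6-fold higher number from compound 3 to compound 4 (0.66 log units; beyond the scatter). Compound 4 is therefore estimated at 350 nM, within a range of 90 nM to 1400 nM.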

Compound 4, half-maximal effective concentration: 155 nM
Compound 4: middle estimate off by 2.3-fold (0.35 log units), on the high side; the range from low to high includes it.
By their numbers in this assay, from the lowest: compound 1; then compound 3; then compounds 4 and 2 (each within the scatter of the next).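

In this assay, replacing (4-carboxyphenoxy)methyl with 1-(3-carboxyphenoxy)ethyl on the aromatic carbon ortho to the trifluoromethyl group gives a 2.0-fold higher number from compound 3 to compound 4 (0.31 log units; beyond the scatter), so the combined change of the extra methyl and the moved carboxylic acid is a modest one. With the branched carbon kept, 3-carboxyphenoxy in place of (4-carboxyphenyl)(methyl)amino gives a 1.2-fold lower number from compound 2 to compound 4 (0.06 log units; within the scatter), which means that these two groups cannot be told apart on this carbon in this assay, even though they differ in both the linking atom and the place of the acid. The widest step in the set so far is a 13-fold higher number from compound 1 to compound 4 (1.11 log units; beyond the scatter), and it sets 1-(3-carboxyphenoxy)ethyl well apart from the unbranched (4-carboxybenzyl)(methyl)amino group.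

The compounds shown do not separate the share of the extra methyl from that of the moved acid, which 1-(4-carboxyphenoxy)ethyl or (3-carboxyphenoxy)methyl on the same carbon would address, and they leave open how an amide link or a tetrazole in place of the carboxylic acid would read. No supporting evidence is available to explain any of these steps.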